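Cytotoxicity on HEp-2: benzylic substituent series, next compound

The source may report more compounds than this note shows. Statements on the series, on what has been measured and on what is new or still open speak of the compounds shown alone.

Measured so far:
compound 1 `CC(C)CCn1c(Cn2c(=O)n(C(C)C)c3ccccc32)nc2cc(CNC3CC3)ccc21` — 17200 nM
compound 2 `CC(C)CCn1c(Cn2c(=O)n(C(C)C)c3ccccc32)nc2cc(CN(C)C)ccc21` — 5650 nM
compound 3 `CC(C)CCn1c(Cn2c(=O)n(C(C)C)c3ccccc32)nc2cc(CNS(C)(=O)=O)ccc21` — 30800 nM

In an ADME assay on HEp-2 cells (Homo sapiens) for cytotoxicity (a higher number here means that more compound is tolerated, a lower number that less compound is tolerated), compound 3 gives the highest of the three numbers. Its nearest neighbour is compound 1, with the two values within the scatter of each other. The other step is a 5.5-fold higher number from compound 2 to compound 3 (0.74 log units; beyond the scatter). So only compound 2 is clearly less tolerated than compound 3.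

Compound 4 `CC(C)CCn1c(Cn2c(=O)n(C(C)C)c3ccccc32)nc2cc(CO)ccc21` differs from compound 3 as follows: hydroxy in place of methanesulfonamido on a saturated chain carbon bound to an aromatic carbon.

Among the compounds with values here, no measured step introduces a hydroxy group. The two steps that change the group on the same saturated chain carbon bound to an aromatic carbon are a 1.8-fold higher number from compound 1 to compound 3 (0.25 log units; within the scatter), within the scatter, and a 5.5-fold higher number from compound 2 to compound 3 (0.74 log units; beyond the scatter), modest. A second small neutral group in this position has so far not moved the number far from compound 3, as compound 1 shows. The expectation is therefore a step of a 1.5-fold lower number from compound 3 to compound 4 (0.19 log units; within the scatter), not beyond the scatter, in this assay. Compound 4 is estimated at 20000 nM, with a range of 8000 nM to 50000 nM.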

Compound 4, half-maximal cytotoxic concentration: 31600 nM
Beside the measured number, compound 4's estimate is 1.6-fold (0.20 log units) below it; low and high end bracket the measured number.
By their numbers in this assay, from the lowest: compound 2; then compounds 1, 3 and 4 (each within the scatter of the next).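

In this assay, the heavy-atom count of the group on this saturated chain carbon bound to an aromatic carbon falls from 5 to 1 with no readable change (a 1.0-fold higher number from compound 3 to compound 4 (0.01 log units; within the scatter)), so the full methanesulfonamido group is not required to hold the number at the level of compound 3. Hydroxy also stays within the scatter of cyclopropylamino (a 1.8-fold higher number from compound 1 to compound 4 (0.26 log units; within the scatter)) but stands clear of dimethylamino (a 5.6-fold higher number from compound 2 to compound 4 (0.75 log units; beyond the scatter)), leaving compound 2 as the only one of the four set apart from the others. Nothing available accounts for that separation.

As far as these compounds go, whether another tertiary amine, such as diethylamino or a piperidine, would fall with compound 2 stays open. So does where a carboxylic acid or a methoxy group on this carbon would sit.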